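The source may hold more compounds than are shown below. What is called first, only, known or untested is meant among the compounds shown, and "the series" means these compounds.

Compound 1 `COc1ccccc1/C=C(\C(=O)c1ccc(Br)cc1)S(=O)(=O)c1ccc(C)cc1`: 1000 nM
Compound 2 `COc1ccccc1/C=C(\C(=O)c1ccc(Cl)cc1)S(=O)(=O)c1ccc(C)cc1`: 1000 nM

In a functional assay on DU-145 cells (Homo sapiens) for inhibition, read by trypan blue exclusion, with a stated time of 96 h (on this read-out lower numbers stand for stronger inhibition of growth and higher numbers for weaker inhibition of growth), compound 2 gives 1000 nM, level with compound 1. Among the measured compounds shown here, the one measured step, no change at the digits printed from compound 1 to compound 2 (within the scatter), is chloro in place of bromo on an aromatic carbon, and it lies within the scatter. Compound 3 `Cc1ccc(S(=O)(=O)/C(=C/c2cccs2)C(=O)c2ccc(Cl)cc2)cc1` differs from compound 2 elsewhere: thiophen-2-yl in place of 2-methoxyphenyl on a double-bonded chain carbon bound to a double-bonded chain carbon. For the measured compounds named here, no measured step touches this place, so the data give no direct size or direction for the change, and no shift beyond the scatter is assumed. The expected step is no change at the digits printed from compound 2 to compound 3 (within the scatter). Compound 3 is estimated at 1000 nM, with an expected range of 300 nM to 3500 nM.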

Compound 3, concentration for 50% growth inhibition: 25000 nM
For compound 3 the middle estimate is 25-fold (1.40 log units) below the measured one; the whole stated range lies below it.
By their numbers in this assay, from the lowest: compounds 1 and 2 (each within the scatter of the next); then compound 3.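

In this assay, this place proves far more sensitive than the halogen site: thiophen-2-yl in place of 2-methoxyphenyl gives a 25-fold higher number from compound 2 to compound 3 (1.40 log units; beyond the scatter), a large weakening of growth inhibition, whereas chloro in place of bromo stayed within the scatter. Nothing available here explains this loss. The compounds shown leave open whether the loss goes with the thiophen-2-yl ring itself or with the departure of the methoxy group. An unsubstituted phenyl or a furan-2-yl at this place would bear on that question.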